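Adding 4-Fluorophenyl to Compound 2

The compounds below may be only part of what the source reports. "The series", "measured", "known", "first", "only" and "open" are said of these compounds alone.

In a physicochemical assay for lipophilicity, using the shake flask method, in phosphate buffer, measured as octanol-water partition, with a stated time of 24 h, at pH 7.4 (a higher number here means a more lipophilic compound, a lower number a more polar compound), compound 1 (`Cc1nn(-c2ccccc2F)c2c1C(c1ccc(F)cc1)CS(=O)(=O)O2`) gives 2.13 and compound 2 (`O=S1(=O)CCc2c(C3CC3)nn(-c3ccccc3F)c2O1`) gives 2.09. Compound 2 therefore stands level with compound 1, the two values lying within the scatter of each other. Compound 3 (`O=S1(=O)CC(c2ccc(F)cc2)c2c(C3CC3)nn(-c3ccccc3F)c2O1`) has 4-fluorophenyl in place of hydrogen on a saturated ring carbon of compound 2 (4-fluorophenyl in place of hydrogen on a saturated ring carbon). Within the data shown here, no measured pair shows this change, so the size of the step is uncertain, but a clear rise in this assay is expected. The estimated change is a number 1.01 log units higher from compound 2 to compound 3 (beyond the scatter). For compound 3 the expected value is 3.1, with an estimated range of 2.6 to 3.7.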

Compound 3, partition coefficient: 1.76
The estimate for compound 3 lay 1.34 log units above the measured number, and the stated range ends above it.
By their numbers in this assay, from the lowest: compound 3; then compounds 2 and 1 (each within the scatter of the next).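

In this assay, the step of a number 0.33 log units lower from compound 2 to compound 3 (beyond the scatter) comes with 4-fluorophenyl in place of hydrogen on a saturated ring carbon, so this added aromatic ring lowers the number at this position rather than raising it. With 4-fluorophenyl present in both compounds, the step of a number 0.37 log units lower from compound 1 to compound 3 (beyond the scatter) comes with cyclopropyl in place of methyl on an aromatic carbon. No measurement at hand accounts for either step.

On these data alone, whether an amine or a carboxylic acid on that saturated ring carbon would shift the number further remains open. So does whether a longer chain in place of cyclopropyl would follow the same direction.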